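The compounds below may be only part of what the source reports. "The series", "measured", "known", "first", "only" and "open" are said of these compounds alone.

In a functional assay on NCI-H1650 cells (Homo sapiens) for cytotoxicity, read by MTT assay, with a stated time of 48 h (a lower number here means a stronger inhibitor, a higher number a weaker inhibitor), three compounds that share one core and differ only in the chain on the oxygen have been measured. Compound 1 `CCCCOc1ccc2c(Cl)ccnc2c1` gives 2570 nM, compound 2 `CCCCCCCCOc1ccc2c(Cl)ccnc2c1` gives 3240 nM, and compound 3 `CCCCCCOc1ccc2c(Cl)ccnc2c1` gives 2080 nM. Compound 3 therefore stands level with the other two, since a 1.2-fold lower number from compound 1 to compound 3 (0.09 log units; within the scatter) and a 1.6-fold lower number from compound 2 to compound 3 (0.19 log units; within the scatter) both lie within the scatter of repeated measurements. The next compound is compound 4 `CC(C)Oc1ccc2c(Cl)ccnc2c1`, and the change is isopropyl in place of hexyl on an oxygen on an aromatic ring. Among the measured compounds shown here, no measured compound carries isopropyl, so the measured steps are only an indirect guide. They do show that altering the chain has not yet moved the number beyond the scatter, and the remaining comparison, a 1.3-fold higher number from compound 1 to compound 2 (0.10 log units; within the scatter), is also within it. No real shift in either direction is therefore expected in this assay. The expected step is a 1.3-fold higher number from compound 3 to compound 4 (0.10 log units; within the scatter), which would be no more than scatter. For compound 4 the estimated value is 2600 nM, with an expected range from 1300 nM to 5000 nM.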

Compound 4, half-maximal inhibitory concentration: 2310 nM
Beside the measured number, compound 4's estimate is 1.1-fold (0.05 log units) above it, and the stated range covers the measured number.
By their numbers in this assay, from the lowest: compounds 3, 4, 1 and 2 (each within the scatter of the next).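

With isopropyl in place of hexyl, a branched group joins the straight chains on the oxygen on an aromatic ring, and in this assay this gives a 1.1-fold higher number from compound 3 to compound 4 (0.05 log units; within the scatter), while isopropyl in place of butyl gives a 1.1-fold lower number from compound 1 to compound 4 (0.05 log units; within the scatter). Going from 6 heavy atoms to 3, and from a straight chain to a branched one, therefore leaves the number within the scatter in these compounds. No measurement shown here offers an explanation for this.

Every group shown on this oxygen is a plain carbon chain, so it remains open whether an amine or a carboxylic acid at the end of the chain, or a benzyl group, would move the number beyond the scatter. The compounds also all keep the chlorine on the shared core, so they cannot show how replacing it would affect the number.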